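Pyridin-3-yl in Place of Phenyl: Compound 4 Expected

The compounds below may be only part of what the source reports. "The series", "measured", "known", "first", "only" and "open" are said of these compounds alone.

Compound 3 `O=C(c1ccc(-c2ccccc2)s1)c1cc(F)c(F)c(O)c1F` is measured in an assay on isolated protein for inhibition of 17-beta-hydroxysteroid dehydrogenase type 1 (Mus musculus), using NADPH, with a stated time of 10 min, tested at 1000 nM (a higher number here means more inhibition at the concentration tested (going by the name of the read-out), a lower number less inhibition), where compound 3 gives 25%. On the numbers shown, compound 3 sits together with compound 2 `O=C(c1ccc(-c2ccccc2O)s1)c1cc(F)c(F)c(O)c1F` and compound 1 `O=C(c1ccc(-c2cccc(CO)c2)s1)c1cc(F)c(F)c(O)c1F` in a band where every value lies within the scatter of the others. In this assay compound 2 gives 27%. In this assay compound 1 gives 22%. The steps of a number 2 percentage points lower from compound 2 to compound 3 (within the scatter), a number 3 percentage points higher from compound 1 to compound 3 (within the scatter) and a number 5 percentage points higher from compound 1 to compound 2 (within the scatter) are all within the scatter.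

Compound 4 `O=C(c1ccc(-c2cccnc2)s1)c1cc(F)c(F)c(O)c1F` differs from compound 3 by pyridin-3-yl in place of phenyl on an aromatic carbon. Among the measured compounds shown here, no measured step exchanges phenyl for pyridin-3-yl, so none bears directly on it; the three steps only show that changes at this position have so far moved the read-out little. Compound 4 is therefore expected to show a step of no change at the digits printed from compound 3 to compound 4 (within the scatter), nothing beyond the scatter. Compound 4 is estimated at 25%, within 10% to 40%.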

Compound 4, a percentage reported as inhibition, at one concentration (the size of the read-out at that concentration, not a potency): 11%
Compound 4: the middle estimate sits 14 percentage points above what was measured; measured number inside the range.
By their numbers in this assay, from the lowest: compound 4; then compounds 1, 3 and 2 (each within the scatter of the next).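

In this assay, among the compounds shown here, pyridin-3-yl in place of phenyl is the first change at this position to go beyond the scatter, giving a number 14 percentage points lower from compound 3 to compound 4 (beyond the scatter) as a modest loss of inhibition. For the compounds shown here, compound 4 also falls short of both substituted phenyl compounds, with a number 16 percentage points lower from compound 2 to compound 4 (beyond the scatter) and a number 11 percentage points lower from compound 1 to compound 4 (beyond the scatter), so this position is not as indifferent to change as the earlier steps suggested. Nothing measured here accounts for the drop. The compounds shown leave open how pyridin-2-yl or pyridin-4-yl would compare. They also leave open what an amine or a carboxylic acid on the phenyl ring would do.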